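This account rests on a few compounds, and the source may have more. Where it says the series, first, only, none or still open, it means among the compounds named here.

In an ADME assay on Vero 76 cells (Chlorocebus sabaeus) for cytotoxicity, read by crystal violet staining, with a stated time of 96 h (a higher number here means that more compound is tolerated, a lower number that less compound is tolerated), compound 3 (`Fc1ccc(NC(=S)Nc2cccc(C(F)(F)F)c2)cc1`) gives 40000 nM, compound 2 (`Fc1ccc(NC(=S)Nc2cccc(C(F)(F)F)c2)cc1Cl`) gives 20000 nM and compound 1 (`CC[C@H]1CC[C@H](c2ccc(NC(=S)Nc3cccc(C(F)(F)F)c3)cc2)CC1`) gives 10000 nM. Compound 3 thus stands clear of compound 1 but not of compound 2. Compound 4 (`FC(F)(F)c1cccc(NC(=S)NCc2ccco2)c1`) carries (furan-2-yl)methyl in place of 4-fluorophenyl on an amide-type nitrogen. The measured steps only exchange substituents on an aromatic carbon, and neither replaces the whole group. One is a 2.0-fold higher number from compound 2 to compound 3 (0.30 log units; within the scatter), within the scatter, and the other is a 4.0-fold higher number from compound 1 to compound 3 (0.60 log units; beyond the scatter), modest and beyond it. Within the data shown here, with steps this small as the only guide, no change beyond the scatter is expected, and the estimated step is a 1.3-fold higher number from compound 3 to compound 4 (0.10 log units; within the scatter). Compound 4 is expected near 50000 nM, with an estimated range of 20000 nM to 100000 nM.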

Compound 4, half-maximal cytotoxic concentration: 50000 nM
Beside the measured number, compound 4's estimate shows no gap at the digits printed, and the stated range covers the measured number.
By their numbers in this assay, from the lowest: compounds 1, 2, 3 and 4 (each within the scatter of the next, the first and the last beyond it).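

In this assay, among these compounds, the entire 4-fluorophenyl on the amide-type nitrogen is exchanged for (furan-2-yl)methyl, where the earlier steps touched only substituents on an aromatic carbon, and the result is a 1.3-fold higher number from compound 3 to compound 4 (0.10 log units; within the scatter). Here a six-membered aromatic ring of carbon only and a five-membered aromatic ring with 1 hetero atom give numbers that cannot be told apart. No measurement shown offers a cause for this. The compounds shown leave open whether a longer chain, an amine or a carboxylic acid on this nitrogen would stay equally close.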